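The source may report more compounds than this note shows. Statements on the series, on what has been measured and on what is new or still open speak of the compounds shown alone.

Three compounds have been measured in a functional assay on SMMC-7721 cells (Homo sapiens) for inhibition, read by CCK-8 assay, with a stated time of 72 h, tested at 2 uM; a higher number here means more inhibition of growth at the concentration tested, a lower number less inhibition of growth:

compound 1, `Nc1ccccc1NC(=O)c1ccc(CSc2ccc(Br)cc2)cc1`, giving 10%
compound 2, `Nc1ccccc1NC(=O)c1ccc(CSc2ccc(C(F)(F)F)cn2)cc1`, giving 12.4%
compound 3, `Nc1ccccc1NC(=O)c1ccc(CSc2cccc(F)c2)cc1`, giving 18.6%

Compound 3 holds the highest of the three numbers, but the spread is small: compound 2 sits close to it, and the step of a number 8.6 percentage points higher from compound 1 to compound 3 (within the scatter) is the largest gap in the set and still lies within the scatter. The three results therefore cannot be ordered with confidence.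

Compound 4, `CCc1ccc(SCc2ccc(C(=O)Nc3ccccc3N)cc2)cc1`, is the next compound in this assay. The change from compound 3 is 4-ethylphenyl in place of 3-fluorophenyl on a sulfur. Going by the values given here, the only measured step that touches the same position is the one from compound 1 to compound 3, and it stayed within the scatter; no measured compound carries a 4-ethylphenyl, so nothing speaks directly for this group. On this basis compound 4 is expected to show no step beyond the scatter, an estimated step of a number 3.6 percentage points lower from compound 3 to compound 4 (within the scatter) in this assay. The expected value for compound 4 is 15%, with a range from 3% to 30%.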

Compound 4, percent growth inhibition at one concentration: 25.7%
Estimate against measurement, compound 4: 10.7 percentage points below; the measured number falls inside the stated range.
By their numbers in this assay, from the lowest: compounds 1, 2, 3 and 4 (each within the scatter of the next, the first and the last beyond it).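

Among the steps at this place on the sulfur, one now lies beyond the scatter in this assay (a number 15.7 percentage points higher from compound 1 to compound 4 (beyond the scatter)), with ethyl in place of bromo on an aromatic carbon, though the step is modest. The step from the 3-fluorophenyl of the nearest earlier compound (a number 7.1 percentage points higher from compound 3 to compound 4 (within the scatter)) stays within the scatter, so the data separate 4-ethylphenyl from 4-bromophenyl but not from 3-fluorophenyl. No independent measurement bears on what lies behind this difference.

The compounds shown leave open whether a longer chain, such as a propyl group, or an amine in place of the ethyl would give a larger step at this place. They also leave open how compound 4 behaves at any other concentration, since only a single tested concentration is shown.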